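Pyrrolidinyl in place of propylamino on a purine-like core

The source may hold more compounds than are shown below. What is called first, only, known or untested is meant among the compounds shown, and "the series" means these compounds.

Measured compounds:
compound 1 `CN(C)c1ncnc2c1ncn2Cc1c(F)cccc1F`, 2.2 mg/kg
compound 2 `CCCNc1ncnc2c1ncn2Cc1ccccc1F`, 5.1 mg/kg

In a functional assay on the whole organism with Rattus norvegicus as the target, in the maximal electroshock model (on this read-out lower numbers stand for an effect already at smaller amounts and higher numbers for an effect only at larger amounts of compound), compound 2 holds the higher of the two numbers, and compound 1 gives a number lower by more than the scatter. Compound 3 `Fc1ccccc1Cn1cnc2c(N3CCCC3)ncnc21` is not yet measured. It differs from compound 2 by one change: pyrrolidin-1-yl in place of propylamino on an aromatic carbon. For the measured compounds named here, no step between measured compounds is known, so the size of the step is open; compound 3 is expected to show a step of a 1.5-fold lower number from compound 2 to compound 3 (0.16 log units; within the scatter), a modest move toward lower numbers. Compound 3 is estimated at 3.5 mg/kg, within 1.5 mg/kg to 8 mg/kg.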

Compound 3, dose for half-maximal effect: 12.5 mg/kg
Compound 3: middle estimate off by 3.6-fold (0.55 log units), on the low side, outside the stated range (above it).
By their numbers in this assay, from the lowest: compound 1; then compound 2; then compound 3.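

In this assay, pyrrolidin-1-yl in place of propylamino gives a 2.5-fold higher number from compound 2 to compound 3 (0.39 log units; beyond the scatter), so this position on the shared core responds to the choice of amine and does not accept this exchange without a loss of potency. The exchange both adds a five-membered ring and removes the hydrogen-bond donor, and this single pair cannot separate the two. Nothing measured here explains the shift. Going by these compounds, it remains open how a piperidin-1-yl or morpholin-4-yl ring would compare at this position. The same holds for a methyl(propyl)amino group, which keeps the chain without the amine hydrogen, and for a longer chain such as butylamino.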